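From methylamino to amino on the shared core

This account rests on a few compounds, and the source may have more. Where it says the series, first, only, none or still open, it means among the compounds named here.

- compound 1 `CNC1=C(SC)C(=O)c2ncccc2C1=O`: 3440 nM
- compound 2 `CNC1=C(Sc2ccccc2)C(=O)c2ncccc2C1=O`: 8030 nM
- compound 3 `CNC1=C([S+](C)[O-])C(=O)c2ncccc2C1=O`: 12100 nM

These three values come from a functional assay on HL-60 cells (Homo sapiens) for antiproliferative activity, read by MTT assay, with a stated time of 48 h; on this read-out lower numbers stand for stronger inhibition and higher numbers for weaker inhibition. Compound 1, at 3440 nM, has the lowest number of the three and is the most potent, since its steps to both others lie beyond the scatter. Compound 4 `CSC1=C(N)C(=O)c2cccnc2C1=O` has not yet been measured. It departs from compound 1 by one change: hydrogen in place of methyl on an amine nitrogen. In words, hydrogen takes the place of methyl on an amine nitrogen, so methylamino becomes amino.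

Among the measured compounds shown here, no measured step touches this nitrogen, so the evidence is only indirect. All three measured steps concern the group on sulfur. Two were modest: a 2.3-fold higher number from compound 1 to compound 2 (0.37 log units; beyond the scatter) and a 3.5-fold higher number from compound 1 to compound 3 (0.55 log units; beyond the scatter). The third, a 1.5-fold higher number from compound 2 to compound 3 (0.18 log units; within the scatter), stayed within the scatter. These steps show that the numbers in this assay moved only modestly across this small set, but they give no direction for a change at the amine nitrogen. The best expectation is therefore no shift beyond the scatter, with real uncertainty either way. The expected outcome is a 1.0-fold higher number from compound 1 to compound 4 (0.01 log units; within the scatter). For compound 4 the estimated value is 3500 nM, with an expected range from 1200 nM to 10000 nM.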

Compound 4, half-maximal inhibitory concentration: 7640 nM
Beside the measured number, compound 4's estimate is 2.2-fold (0.34 log units) below it; low and high end bracket the measured number.
By their numbers in this assay, from the lowest: compound 1; then compounds 4, 2 and 3 (each within the scatter of the next).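

Among the compounds shown here, the amine nitrogen, which no earlier step had touched, turns out to respond in this assay: hydrogen in place of methyl gives a 2.2-fold higher number from compound 1 to compound 4 (0.35 log units; beyond the scatter), so the methyl on this nitrogen is not a silent part of compound 1. The step is modest, like the two steps from compound 1 at the group on sulfur, which means that changes at two different places on the shared core have now each moved the number beyond the scatter, and compound 1 keeps the lowest number of the four, with its steps to compounds 2, 3 and 4 all beyond the scatter. Why methylamino reads lower than amino cannot be said, since nothing on hand gives any measured property that bears on this step.

The compounds shown leave open how the number responds when the methyl on this nitrogen gives way to something larger, such as an ethyl group, a longer chain or an acetyl group. They also leave open whether hydrogen in place of methyl on this nitrogen would have a similar effect with phenyl on the sulfur, as in compound 2, or with the sulfur group of compound 3.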